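Ring contraction of the thiocarbonyl amine in the amidrazone series

This account rests on a few compounds, and the source may have more. Where it says the series, first, only, none or still open, it means among the compounds named here.

Three compounds of the series have a number in a functional assay on HeLa cells (Homo sapiens) for cytotoxicity, read by MTT assay, with a stated time of 72 h; on this read-out lower numbers stand for stronger inhibition and higher numbers for weaker inhibition. Compound 2 `Cc1cccc(/C(N)=N/NC(=S)N2CCCCC2)n1` gives 2000 nM and stands lowest of the three. Compound 3 `Cc1ccnc(/C(N)=N/NC(=S)N2CCCCCC2)c1` gives 7000 nM, a number beyond the scatter above that of compound 2, and compound 1 `Cc1ccnc(/C(N)=N/NC(=S)N2CCSCC2)c1` gives 15500 nM, further above still. Among the measured compounds shown here, compound 1 and compound 3 carry a core that is not that of compound 2, so no pair of measured compounds differs in one place, and the spread among the three cannot be assigned to the amine on the thiocarbonyl carbon alone.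

Compound 4 `Cc1cccc(/C(N)=N/NC(=S)N2CCCC2)n1` is the next member to be measured. It differs from compound 2 in one place: pyrrolidin-1-yl in place of piperidin-1-yl on a thiocarbonyl carbon. For the measured compounds named here, nothing measured so far tracks this single change on the core of compound 2, and the two cyclic amines that have been compared across different cores give no direction that can be carried over.

The step from compound 2 to compound 4 is therefore expected to be small, at most a modest move in either direction and most likely within the scatter, as a 1.5-fold higher number from compound 2 to compound 4 (0.18 log units; within the scatter) states. Compound 4 is estimated at 3000 nM in this assay, with a range from 1000 nM to 9000 nM.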

Compound 4, half-maximal inhibitory concentration: 2700 nM
Estimate against measurement, compound 4: 1.1-fold (0.05 log units) above; the range from low to high includes it.
By their numbers in this assay, from the lowest: compounds 2 and 4 (each within the scatter of the next); then compound 3; then compound 1.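

In this assay, the first single change followed on the core of compound 2 reads a 1.4-fold higher number from compound 2 to compound 4 (0.13 log units; within the scatter), so pyrrolidin-1-yl and piperidin-1-yl on a thiocarbonyl carbon cannot be told apart on this core. The earlier compounds shown here gave no pair differing in one place; this pair now shows that, on this core, this position accepts the five-membered ring in place of the six-membered ring with the two numbers remaining within the scatter of each other. No measurement of any property of these two amines is available to bear on this result.

On these data alone, whether the same change would also read flat on the core shared by compound 1 and compound 3 remains open, and the spread among those compounds and compound 2 still cannot be assigned to either the core or the amine. Also open, as far as these compounds go, is how far the amine on the thiocarbonyl carbon can depart from these two rings on the core of compound 2: azetidin-1-yl, morpholin-4-yl or an open-chain dimethylamino group would test whether the flat reading extends beyond this pair.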